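Replacing Dimethylamino with Fluoro and Methoxy on the Aryl Ring

The source may report more compounds than this note shows. Statements on the series, on what has been measured and on what is new or still open speak of the compounds shown alone.

Going by the values given here, in an assay on CHO cells for antagonist activity at transient receptor potential cation channel subfamily V member 1 (Homo sapiens), read by FLIPR (a higher number here means a weaker inhibitor, a lower number a stronger inhibitor), compound 2 `CC(C(=O)NCc1ccc(C(F)(F)F)nc1-c1ccc(N(C)C)cc1)c1ccc(NS(C)(=O)=O)c(F)c1` gives 3.2 nM, the lowest of the two numbers measured so far. Compound 1 `CC(C(=O)NCc1ccc(C(F)(F)F)nc1-c1ccccc1F)c1ccc(NS(C)(=O)=O)c(F)c1` gives 63.3 nM. Among the compounds with values here, the single measured step, a 20-fold lower number from compound 1 to compound 2 (1.30 log units; beyond the scatter), concerns the same aromatic carbon that compound 3 `COc1ccc(-c2nc(C(F)(F)F)ccc2CNC(=O)C(C)c2ccc(NS(C)(=O)=O)c(F)c2)cc1F` alters: 3-fluoro-4-methoxyphenyl in place of 4-(dimethylamino)phenyl on an aromatic carbon. Within the data shown here, no measured pair separates these two aryl groups directly, so the author expects a rise smaller than that earlier step, a 2.5-fold higher number from compound 2 to compound 3 (0.40 log units; beyond the scatter), leaving the compound clearly nearer compound 2 than compound 1. Compound 3 is therefore estimated at 8 nM, expected to fall between 2 nM and 30 nM.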

Compound 3, inhibition constant: 4.2 nM
Compound 3: the middle estimate sits 1.9-fold (0.28 log units) above what was measured, and the stated range covers the measured number.
By their numbers in this assay, from the lowest: compounds 2 and 3 (each within the scatter of the next); then compound 1.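

In this assay 3-fluoro-4-methoxyphenyl and 4-(dimethylamino)phenyl cannot be told apart at this position, with a 1.3-fold higher number from compound 2 to compound 3 (0.12 log units; within the scatter) on the shared core. Set against 2-fluorophenyl, the new group gives a 15-fold lower number from compound 1 to compound 3 (1.18 log units; beyond the scatter), so among these compounds the low number does not depend on the dimethylamino group. No supporting evidence bears on why these two groups read alike.

Going by these compounds, whether the fluoro or the methoxy matters more remains open, since the two enter together. Also open, on these data alone, is how a morpholine or a carboxylic acid on the phenyl ring would read.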